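From Ethoxy to Methoxy on a Shared Core

The source may hold more compounds than are shown below. What is called first, only, known or untested is meant among the compounds shown, and "the series" means these compounds.

In a functional assay for inhibition, with Cavia porcellus as the target (on this read-out lower numbers stand for stronger inhibition and higher numbers for weaker inhibition), compound 2 (`CCO/C(O)=C1\C(C)=NC(C)=C([N+](=O)[O-])C1c1ccccn1`) reads 5000 nM and holds the higher of the two single numbers, with compound 1 (`CC1=NC(C)=C([N+](=O)[O-])C(c2ccccn2)/C1=C(\O)OC1CCCC1`) at 450 nM as its nearest neighbour. Compound 3 (`CC1=NC(C)=C([N+](=O)[O-])C(c2ccccn2)/C1=C(\O)OC1CCCCC1`) gives 842 nM; 5270 nM; 74.8 nM (3 entries) and so offers no single number. Compound 4 (`CO/C(O)=C1\C(C)=NC(C)=C([N+](=O)[O-])C1c1ccccn1`) remains unmeasured; it carries hydrogen in place of methyl on a saturated chain carbon bound to an oxygen on an unsaturated carbon. Within the data shown here, the one measured step bearing on this, an 11-fold higher number from compound 1 to compound 2 (1.05 log units; beyond the scatter) with ethyl in place of cyclopentyl, was large, but the present change is much smaller, so a 1.4-fold higher number from compound 2 to compound 4 (0.15 log units; within the scatter) is expected to stay small, with no shift beyond the scatter. Compound 4 is estimated at 7000 nM (range 2000 nM to 20000 nM) in this assay for now.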

Compound 4, half-maximal inhibitory concentration: 212000 nM
Estimate against measurement, compound 4: 30-fold (1.48 log units) below; the whole stated range lies below it.
By their numbers in this assay, from the lowest: compound 1; then compound 2; then compound 4.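

Even the removal of a single carbon matters at this oxygen in this assay: going from ethoxy to methoxy gives a 42-fold higher number from compound 2 to compound 4 (1.63 log units; beyond the scatter), so a change this small is enough to produce a large step. Methyl in place of cyclopentyl on an oxygen on an unsaturated carbon gives a 470-fold higher number from compound 1 to compound 4 (2.67 log units; beyond the scatter), and the numbers of these three compounds rise from cyclopentyl through ethyl to methyl.

From the compounds shown here alone, compound 3 does not settle how its larger ring compares with cyclopentyl: the several entries of compound 3 in this assay, 842 nM; 5270 nM; 74.8 nM (3 entries) How a propyl, isopropyl or phenyl group on the same oxygen would read remains open.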